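This account rests on a few compounds, and the source may have more. Where it says the series, first, only, none or still open, it means among the compounds named here.

Measured so far:
compound 1 `CCCCC(O)Cn1cc(CN(C)CC2CCCCC2)nn1`: 47%
compound 2 `O=C(OC1CCCCC1n1cc(CN2CCC(c3ccccc3)CC2)nn1)c1ccccc1`: 16%

In an assay on nucleic acid for inhibition of Nucleic Acid, read by fluorescence, tested at 100 uM (on this read-out higher numbers stand for more inhibition at the one concentration tested (going by the name of the read-out) and lower numbers for less inhibition), compound 2 stands as the lower of the two numbers; compound 1 sits higher by a gap that is beyond the usual scatter. Compound 3 `O=C(COc1ccccc1)OC1CCCCC1n1cc(CN2CCC(c3ccccc3)CC2)nn1` has not yet been measured. It differs from compound 2 in one place only: phenoxymethyl in place of phenyl on a carbonyl carbon. Within the data shown here, no two measured compounds differ from each other in just one place, so there is no measured step of that kind to draw on, and the value of compound 2 is the only anchor. On that basis the step from compound 2 to compound 3 is expected to be small, a number 2 percentage points higher from compound 2 to compound 3 (within the scatter), staying within the scatter rather than moving clearly in either direction. Compound 3 is therefore estimated in this assay at 18%, in a range from 5% to 35%.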

Compound 3, a percentage reported as inhibition, at one concentration (the size of the read-out at that concentration, not a potency): 42%
Compound 3: the middle estimate sits 24 percentage points below what was measured, outside the stated range (above it).
By their numbers in this assay, from the lowest: compound 2; then compounds 3 and 1 (each within the scatter of the next).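

In this assay, among these compounds, phenoxymethyl in place of phenyl on a carbonyl carbon gives a number 26 percentage points higher from compound 2 to compound 3 (beyond the scatter) and provides the first single-place comparison. This one pair shows that the group at this position can change the read-out even when the rest of the structure stays the same. The entering group is larger and carries an oxygen counted as a hydrogen-bond acceptor, but no available measurement shows which of these differences, if either, accounts for the rise.

The compounds shown leave open whether the oxygen matters or whether the longer link to the phenyl ring is enough, a question that a phenethyl group on the same carbonyl carbon could address. They also leave open how a non-aromatic group, such as an aminomethyl group, would behave there.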